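This account rests on a few compounds, and the source may have more. Where it says the series, first, only, none or still open, it means among the compounds named here.

Series notes, oxazolidinone hydrazone set.

Compound 1 `CC(=O)NC[C@H]1CN(c2ccc(-c3ccc(/C=N/N4CCSCC4)nc3)c(F)c2)C(=O)O1` is the reference point here. In an ADME assay on isolated protein for inhibition of Amine oxidase [flavin-containing] A (Homo sapiens), read by luminescence, with stated times of 15 min and 60 min, tested at 30 uM (on this read-out higher numbers stand for more inhibition at the one concentration tested (going by the name of the read-out) and lower numbers for less inhibition), compound 1 gives 75%. Compound 2 `CC(=O)NC[C@H]1CN(c2ccc(-c3ccc(/C=N/N4CCSCC4)c(O)c3)c(F)c2)C(=O)O1` carries a hydroxy-substituted phenyl in place of the pyridine of compound 1. In this assay compound 2 gives 62%. Of the two numbers, compound 1 stands highest, with the value of compound 2 sitting lower by a gap beyond the usual scatter. For the measured compounds named here, no pair of measured compounds differing in a single place is available, so no measured single-point step can be quoted.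

Compound 3 `CC(=O)NC[C@H]1CN(c2ccc(-c3ccc(/C=N/N4CCN(C)CC4)nc3)c(F)c2)C(=O)O1` has not yet been measured in this assay. The change from compound 1 to compound 3 is 4-methylpiperazin-1-yl in place of thiomorpholin-4-yl on a double-bonded nitrogen. Going by the values given here, with only the two readings above to go on, and no measured step on this position, the change is expected to cost little; the step of a number 10 percentage points lower from compound 1 to compound 3 (within the scatter) is expected to stay within or just beyond the usual scatter, on the downward side. Compound 3 is estimated at 65% in this assay, with a range from 40% to 85%.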

Compound 3, a percentage reported as inhibition, at one concentration (the size of the read-out at that concentration, not a potency) in the Amine oxidase [flavin-containing] A assay: 79%
Compound 3: the middle estimate sits 14 percentage points below what was measured; the range from low to high includes it.
By their numbers in the Amine oxidase [flavin-containing] A assay, from the lowest: compound 2; then compounds 1 and 3 (each within the scatter of the next).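

For the compounds shown here, in the Amine oxidase [flavin-containing] A assay, the replacement of thiomorpholin-4-yl by 4-methylpiperazin-1-yl on a double-bonded nitrogen gives the first single-place step, a number 4 percentage points higher from compound 1 to compound 3 (within the scatter), so this position accepts a ring with one more heavy atom and a second nitrogen in place of sulfur without a reading that can be told apart from compound 1. In a physicochemical assay for solubility, read by spectrophotometry (a higher number here means a more soluble compound, a lower number a less soluble compound), compound 1 gives 57 ug/mL and compound 3 gives 63 ug/mL, and the step of a 1.1-fold higher number from compound 1 to compound 3 (0.04 log units; within the scatter) shows that this read-out does not separate the two groups either. No measurement to hand bears on why the two groups read alike.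

Still open, going by these compounds, is whether a group of another kind on the same nitrogen, such as morpholin-4-yl, an open-chain dimethylamino group or a carboxylic acid on the ring, would move either read-out beyond the scatter. Going by these compounds alone, also open is whether 4-methylpiperazin-1-yl would behave the same way on the hydroxy-substituted phenyl of compound 2, since the one step in hand rests on the pyridine of compound 1.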